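The compounds below may be only part of what the source reports. "The series", "measured", "known", "first", "only" and "open" are said of these compounds alone.

Three compounds share one core and were measured in an assay on cells with melanin-concentrating hormone receptor 1 (Homo sapiens) as the target, read by radioligand binding; a lower number here means a stronger inhibitor, a higher number a weaker inhibitor. Compound 1 `Nc1ccc2cccc(OCC3CCCC3)c2n1` carries a cyclopentylmethyl group on the aromatic oxygen, and in this assay compound 1 gives 53 nM. Compound 2 `CC(C)Oc1cccc2ccc(N)nc12` carries an isopropyl group there, and compound 2 gives 437 nM. Compound 3 `CC(C)OCCOc1cccc2ccc(N)nc12` carries a 2-isopropoxyethyl group. The value of compound 3, > 2000 nM, is a limit of this assay and not a number, so compound 3 stands at the limit of > 2000 nM in this assay, at which 1 of the 3 values shown sits, and is the weakest of the three. The step of an at least 37-fold higher number from compound 1 to compound 3 (1.57 log units; beyond the scatter) was the largest; an at least 4.5-fold higher number from compound 2 to compound 3 (0.66 log units; beyond the scatter) and an 8.2-fold higher number from compound 1 to compound 2 (0.92 log units; beyond the scatter) also went beyond the scatter.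

Compound 4 `CC1CCC(Oc2cccc3ccc(N)nc23)C1` differs from compound 3 by 3-methylcyclopentyl in place of 2-isopropoxyethyl on an oxygen on an aromatic ring. This removes the ether chain that in compound 3 went with the weakest value and brings back a five-membered ring of carbon resembling that of compound 1. Given an at least 37-fold higher number from compound 1 to compound 3 (1.57 log units; beyond the scatter), the expected step of an at least 25-fold lower number from compound 3 to compound 4 (1.39 log units; beyond the scatter) for compound 4 is a large fall in this assay. The estimate for compound 4 is 80 nM, with a range from 20 nM to 400 nM.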

Compound 4, half-maximal inhibitory concentration: 823 nM
Estimate against measurement, compound 4: 10-fold (1.01 log units) below; the whole stated range lies below it.
By their numbers in this assay, from the lowest: compound 1; then compounds 2 and 4 (each within the scatter of the next). At a limit, above all of these: compound 3.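

Closing a five-membered ring of carbon in place of the ether chain helps in this assay, with an at least 2.4-fold lower number from compound 3 to compound 4 (0.38 log units; beyond the scatter) as the step, but that step is only a bound, as it starts from a limit and not a number: the limit of > 2000 nM in this assay, at which 1 of the 4 values shown sits. The ring alone does not restore what compound 1 has, since a 16-fold higher number from compound 1 to compound 4 (1.19 log units; beyond the scatter) shows that cyclopentylmethyl and 3-methylcyclopentyl are not equivalent on this oxygen. With a 1.9-fold higher number from compound 2 to compound 4 (0.27 log units; within the scatter) as the step, 3-methylcyclopentyl cannot be told apart from isopropyl here.

The compounds shown leave open whether the gap to compound 1 comes from the methyl on the ring or from how the ring is joined to the oxygen, which a plain cyclopentyl group would help to separate. They also leave open how a cyclohexylmethyl group would fare on this oxygen.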